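Triazole nitrogen substituent swap in an adenosine binding series

The source may report more compounds than this note shows. Statements on the series, on what has been measured and on what is new or still open speak of the compounds shown alone.

Measured so far:
compound 1 `CNC(=O)[C@@]12C[C@@H]1[C@@H](n1cnc3c(NCc4cccc(Cl)c4)nc(C#CCCCCc4cn(-c5ccc(N)cc5)nn4)nc31)[C@H](O)[C@@H]2O` — 87.1 nM
compound 2 `C#CCCCC#Cc1nc(NCc2cccc(Cl)c2)c2ncn([C@@H]3[C@H](O)[C@H](O)[C@]4(C(=O)NC)C[C@H]34)c2n1` — 23.6 nM

Two compounds of the series have numbers in an assay on CHO cells for displacement of a labelled ligand from adenosine receptor A3 (Homo sapiens), read by scintillation counting; a higher number here means a weaker inhibitor, a lower number a stronger inhibitor. Compound 1 gives 87.1 nM; compound 2 gives 23.6 nM. Compound 1 has the highest number of the two, and compound 2 sits at a lower number, a gap beyond the scatter. Going by the values given here, the two structures differ in more than one place, so no single step links them; their values show only that compound 2 is the stronger inhibitor of the pair.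

Compound 3 `CNC(=O)[C@@]12C[C@@H]1[C@@H](n1cnc3c(NCc4cccc(Cl)c4)nc(C#CCCCCc4cn(CCCCN)nn4)nc31)[C@H](O)[C@@H]2O` is not yet measured. It differs from compound 1 in one place: 4-aminobutyl in place of 4-aminophenyl on an aromatic nitrogen. Among the compounds with values here, no pair of measured compounds shows this change, so the size and direction of the step rest on nothing measured directly. A modest step toward a lower number is expected, a 1.5-fold lower number from compound 1 to compound 3 (0.16 log units; within the scatter), though a step no larger than the scatter is at least as plausible. For compound 3 the estimate in this assay is 60 nM, with a range from 15 nM to 250 nM.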

Compound 3, inhibition constant: 47 nM
Beside the measured number, compound 3's estimate is 1.3-fold (0.11 log units) above it; low and high end bracket the measured number.
By their numbers in this assay, from the lowest: compounds 2, 3 and 1 (each within the scatter of the next, the first and the last beyond it).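

Going by these compounds alone, replacing 4-aminophenyl with 4-aminobutyl on the aromatic nitrogen of the five-membered aromatic ring gives a 1.9-fold lower number from compound 1 to compound 3 (0.27 log units; within the scatter) in this assay and is the first single-place step read at this position. The six-membered aromatic ring of carbon only can therefore give way to an open chain with no ring without a step beyond the scatter, and compound 1 and compound 3 cannot be told apart in this measurement. Both substituents end in an amine, and nothing measured here gives a reason for this result.

As far as these compounds go, the part played by that terminal amine remains open: a plain butyl chain, a 4-hydroxybutyl chain or a chain ending in a carboxylic acid would test it directly. Chain length also remains open, as an aminopropyl or aminohexyl chain in place of 4-aminobutyl would show whether the number holds when the amine sits closer to or further from the shared core.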